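This account rests on a few compounds, and the source may have more. Where it says the series, first, only, none or still open, it means among the compounds named here.

Measured compounds in a functional assay on the whole organism (Tail, strain ICR) with Mus musculus as the target, in the tail flick test, with a stated time of 120 min, at a dose of 6.25 umol/kg by the oral route; a lower number here means a weaker effect, a higher number a stronger effect of the compound at the dose given:
compound 1 `NCCCC[C@H](NC(=O)CN(c1nc(Cl)nc2[nH]cnc12)C1CC1)C(=O)OCc1ccccc1` gives 9.01%
compound 2 `O=C(CN(c1nc(Cl)nc2[nH]cnc12)C1CC1)NCC(=O)OCc1ccccc1` gives 8.04%
compound 3 `N=C(N)NCCC[C@H](NC(=O)CN(c1nc(Cl)nc2[nH]cnc12)C1CC1)C(=O)O` gives 9.52%

All three values lie within the scatter of one another, so compound 3 is not separated from compound 1 or compound 2 on these numbers. Among the measured compounds shown here, the one step with a single change, a number 1 percentage points lower from compound 1 to compound 2 (within the scatter), removed a whole side chain from the same kind of carbon and left the read-out essentially flat.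

Compound 4 `CC(C)C[C@H](NC(=O)CN(c1nc(Cl)nc2[nH]cnc12)C1CC1)C(=O)O` differs from compound 3 by a group of 3 heavy atoms (3 carbon; no ring) in place of a group of 6 heavy atoms (3 carbon, 3 nitrogen; no ring), on a saturated chain carbon, two bonds along the chain from an amide-type nitrogen and a carbonyl carbon. Given that the removal of a similar chain in a number 1 percentage points lower from compound 1 to compound 2 (within the scatter) produced no movement beyond the scatter, no step beyond the scatter is expected here either: the estimated step is a number 0.5 percentage points lower from compound 3 to compound 4 (within the scatter). Compound 4 is therefore estimated at 9%, with a range from 3% to 16%.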

Compound 4, a percentage reported as activity, at one dose (the size of the read-out at that dose, not a potency): 9.44%
Compound 4: the middle estimate sits 0.4 percentage points below what was measured; the range from low to high includes it.
By their numbers in this assay, from the lowest: compounds 2, 1, 4 and 3 (each within the scatter of the next).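

At the saturated chain carbon, two bonds along the chain from an amide-type nitrogen and a carbonyl carbon, isopropyl in place of the group of 6 heavy atoms gives a number 0.1 percentage points lower from compound 3 to compound 4 (within the scatter) in this assay for this pair. With the acid kept, a side chain with no hydrogen-bond donors therefore reads the same as one carrying 3 of them. Nothing on hand explains this flat read-out.

Going by these compounds, whether a benzyl group on this carbon would move the read-out beyond the scatter remains open. So does the effect of a methyl ester in place of the carboxylic acid.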